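Silyl ether in place of acetate on the saturated ring carbon

This account rests on a few compounds, and the source may have more. Where it says the series, first, only, none or still open, it means among the compounds named here.

Compound 3, `COc1cc(C2=C(c3cc(C)c(OC)c(C)c3)C(OC(C)=O)CC2=O)cc(OC)c1OC`, stands at the limit of an ADME assay on HEK293 cells (Homo sapiens) for cytotoxicity, read by MTT assay, with a stated time of 72 h (a lower number here means a stronger inhibitor, a higher number a weaker inhibitor), with > 100 ug/mL, a limit rather than a number. Compound 1, `COCOc1cc(C2=C(c3cc(OC)c(OC)c(OC)c3)C(=O)CC2O[SiH2]C(C)(C)C)ccc1OC`, also sits at this limit and gives > 100 ug/mL in this assay. Among the compounds with values here, compound 2, `COc1ccc(OC)c(C2=C(c3cc(OC)c(OC)c(OC)c3)C(=O)CC2O[SiH2]C(C)(C)C)c1`, gives 9.5 ug/mL in this assay, and the step of an at least 10-fold lower number from compound 1 to compound 2 (1.02 log units; beyond the scatter) is the only measured step in the set. Two of the three values shown sit at the limit of > 100 ug/mL in this assay, at which 2 of the 3 values shown sit.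

Compound 4 is `COc1cc(C2=C(c3cc(C)c(OC)c(C)c3)C(O[SiH2]C(C)(C)C)CC2=O)cc(OC)c1OC`. The change from compound 3 is a group of 5 heavy atoms (4 carbon, 1 silicon; no ring) in place of a group of 3 heavy atoms (2 carbon, 1 oxygen; no ring), on an oxygen on a saturated carbon. Within the data shown here, no measured step touches this position; the one step recorded swaps an aryl group on a double-bonded ring carbon and is large, but it says nothing about the oxygen on the saturated carbon. Compounds 1 and 2 both carry the entering group and fall on either side of the limit, so the group itself fixes no level. Compound 4 is therefore expected to remain near the limit, with a step of a number no higher from compound 3 to compound 4 (the limit leaves the size open) expected to stay within the scatter. The estimate for compound 4 in this assay is 100 ug/mL, between 30 ug/mL and 300 ug/mL.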

Compound 4, half-maximal inhibitory concentration: 29 ug/mL
Compound 4: the middle estimate sits 3.4-fold (0.54 log units) above what was measured; measured number outside the range, below it.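

In this assay the oxygen on the saturated carbon now carries a measured change, with an at least 3.4-fold lower number from compound 3 to compound 4 (0.53 log units; beyond the scatter) on going from acetyl to the silyl ether. With the silyl ether held, the aryl group on the double-bonded ring carbon still moves the number, with a 3.1-fold higher number from compound 2 to compound 4 (0.48 log units; beyond the scatter) for 4-methoxy-3,5-dimethylphenyl in place of 2,5-dimethoxyphenyl and an at least 3.4-fold lower number from compound 1 to compound 4 (0.53 log units; beyond the scatter) for the same group in place of 4-methoxy-3-(methoxymethoxy)phenyl. On these data alone, compound 3 stands at a limit and not a number, so the full size of the change from acetyl stays unknown: the limit of > 100 ug/mL in this assay, at which 2 of the 4 values shown sit.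

A free hydroxyl or a methyl ether on this oxygen would separate the effect of losing acetyl from that of adding the silyl ether. As far as these compounds go, whether the change from acetyl to silyl ether holds with other aryl groups also stays open.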